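A few compounds are considered here, and "the series" means these few. Any claim that something is new, unique, unknown or untested is made for them only; others in the source may bear on it.

Cytotoxicity notes on the series. Compound 1 `O=c1cc(N2CCN(CC3CCC(OS(=O)(=O)c4cccnc4)CC3)CC2)sc2c([N+](=O)[O-])cc(C(F)(F)F)cc12` sits in an ADME assay on Vero cells (Chlorocebus sabaeus) for cytotoxicity, read by MTT assay, with a stated time of 48 h (on this read-out lower numbers stand for stronger inhibition and higher numbers for weaker inhibition), at a limit of the assay, > 64 ug/mL, so only a bound and no number is known for it. Compound 2 `CC(=O)NC1CCC(CN2CCN(c3cc(=O)c4cc(C(F)(F)F)cc([N+](=O)[O-])c4s3)CC2)CC1` is likewise reported in this assay only as a limit, > 64 ug/mL. Among the compounds with values here, the single one-place step in the set, a step that the two limits leave unreadable from compound 1 to compound 2, therefore cannot be read; both of its ends rest on (the limit of > 64 ug/mL in this assay, at which 2 of the 2 values shown sit). Compound 3 `O=C(OC1CCC(CN2CCN(c3cc(=O)c4cc(C(F)(F)F)cc([N+](=O)[O-])c4s3)CC2)CC1)c1ccc2c(c1)OCC2` is not yet measured; it differs from compound 1 by a group of 11 heavy atoms (9 carbon, 2 oxygen; one five-membered non-aromatic ring with 1 hetero atom, one six-membered aromatic ring of carbon only) in place of a group of 9 heavy atoms (5 carbon, 1 nitrogen, 2 oxygen, 1 sulfur; one six-membered aromatic ring with 1 hetero atom), on an oxygen on a saturated carbon. Within the data shown here, the only measured step that bears on compound 3 is that from compound 1 to compound 2, and its size is unreadable, so no direction can be drawn from it; the working expectation is simply that compound 3 stays at the same limit as compound 1. Compound 3 is accordingly estimated at 80 ug/mL, in the range 40 ug/mL to 160 ug/mL, with the expected step that the limit leaves unreadable from compound 1 to compound 3 being none beyond the scatter.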

Compound 3, half-maximal inhibitory concentration: > 64 ug/mL
Compound 3: no number, only a limit; the forecaster's own chance of this, stated with the estimate: 80%; the middle value is on the limit's open side.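

Compound 3 stands at a limit in this assay, as do compound 1 and compound 2, so no step among these compounds can be read: the limit of > 64 ug/mL in this assay, at which 3 of the 3 values shown sit. The compounds shown leave open whether the groups exchanged here differ at all in cytotoxicity.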